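A few compounds are considered here, and "the series" means these few. Any claim that something is new, unique, unknown or untested is made for them only; others in the source may bear on it.

In an ADME assay on HEK293 cells (Homo sapiens) for cytotoxicity, read by resazurin assay, with a stated time of 72 h (on this read-out lower numbers stand for higher toxicity in this test and higher numbers for lower toxicity in this test), compound 2 `CCc1cccc(CNC(=O)c2nc3cccc(CN(C)Cc4ccc(C(=O)O)cc4)c3c(=O)[nH]2)c1` gives > 20000 nM, which is a limit of the assay and not a number. Compound 1 `CCc1cccc(CNC(=O)c2nc3cccc(COCc4ccc(C(=O)O)cc4)c3c(=O)[nH]2)c1` gives > 40000 nM, which is also a limit. Compound 3 `CCc1cccc(CNC(=O)c2nc3cccc(CSCc4ccc(C(=O)O)cc4)c3c(=O)[nH]2)c1` differs from compound 2 as follows: (4-carboxybenzyl)sulfanyl in place of (4-carboxybenzyl)(methyl)amino on a saturated chain carbon bound to an aromatic carbon. In words, this is (4-carboxybenzyl)sulfanyl in place of (4-carboxybenzyl)(methyl)amino on a saturated chain carbon bound to an aromatic carbon. Within the data shown here, the only measured step bearing on this change is a step that the two limits leave unreadable from compound 1 to compound 2, so it offers no size to carry forward. On that basis, no step beyond the scatter is expected in this assay, in either direction. The expected step is a step that the limit leaves unreadable from compound 2 to compound 3. Compound 3 is estimated at 30000 nM, with an expected range from 15000 nM to 60000 nM.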

Compound 3, half-maximal cytotoxic concentration: > 20000 nM
Compound 3: a limit, no number; the forecaster's own chance of this, stated with the estimate: 75%; the middle value lies beyond the limit too.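

Compound 3 gives > 20000 nM, which is a limit and not a number, so no step can be read among compound 1, compound 2 and compound 3. The compounds shown leave open whether (4-carboxybenzyl)oxy, (4-carboxybenzyl)(methyl)amino and (4-carboxybenzyl)sulfanyl differ at all in this assay.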